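The source may report more compounds than this note shows. Statements on the series, on what has been measured and on what is new or still open speak of the compounds shown alone.

Measured compounds:
Compound 1, `CCNC(=O)Oc1cccc(C(=O)c2nc3ccccc3s2)c1`: 238 nM
Compound 2, `CCCCNC(=O)Oc1cccc(C(=O)c2nc3ccccc3s2)c1`: 103 nM

Going by the values given here, in an assay (strain Wistar) for inhibition of Fatty-acid amide hydrolase 1 (Rattus norvegicus) (a lower number here means a stronger inhibitor, a higher number a weaker inhibitor), compound 2 holds the lowest of the two numbers so far. Its nearest neighbour is compound 1, and the step of a 2.3-fold lower number from compound 1 to compound 2 (0.36 log units; beyond the scatter) separates them, a modest gain that lies beyond the scatter.

Compound 3, `O=C(NC1CCCC1)Oc1cccc(C(=O)c2nc3ccccc3s2)c1`, carries the same core and differs from compound 2 in one place: cyclopentyl in place of butyl on an amide-type nitrogen. The group on the amide-type nitrogen thus changes from an open chain to a carbocyclic ring of nearly the same size.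

Among the compounds with values here, only one measured step bears on this change. That step, a 2.3-fold lower number from compound 1 to compound 2 (0.36 log units; beyond the scatter), showed that enlarging the group on the amide-type nitrogen from ethyl to butyl improved the number modestly. Replacing butyl by cyclopentyl keeps the group at roughly the same bulk, so no comparable gain is firmly indicated; the expected step of a 1.2-fold lower number from compound 2 to compound 3 (0.08 log units; within the scatter) is small and may fall within the scatter. On that basis compound 3 is estimated at 85 nM, with a likely range from 30 nM to 250 nM.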

Compound 3, half-maximal inhibitory concentration: 47 nM
Compound 3: middle estimate off by 1.8-fold (0.26 log units), on the high side; low and high end bracket the measured number.
By their numbers in this assay, from the lowest: compound 3; then compound 2; then compound 1.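

Moving from butyl to cyclopentyl on the amide-type nitrogen in this assay gave a 2.2-fold lower number from compound 2 to compound 3 (0.34 log units; beyond the scatter), which shows that the group at this position need not be an open chain and that a carbocyclic ring can go further than the butyl chain did. Measured against the ethyl compound, the same position spans a 5.1-fold lower number from compound 1 to compound 3 (0.70 log units; beyond the scatter), and across these three compounds the number falls with each larger group, with none going against that order so far. The data shown offer no measurement that explains why the ring gives the lower number.

The step from butyl to cyclopentyl both closes a ring and adds a carbon, so the compounds shown leave open which of the two changes goes with the lower number. A pentyl chain on the same nitrogen would separate those two changes, while a cyclohexyl ring would show whether the fall in the number continues as the ring grows or ends at cyclopentyl.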